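Halogen pattern on the anilino ring in the shared core

A few compounds are considered here, and "the series" means these few. Any claim that something is new, unique, unknown or untested is made for them only; others in the source may bear on it.

Compound 3 `Cc1n[nH]c2ccc(-c3nc4cnc(N5CCN(C)CC5)cn4c3Nc3ccc(Cl)cc3F)cc12` gives 0% in a functional assay on MV4-11 cells (Homo sapiens) for inhibition, with a stated time of 120 h, tested at 10 uM (on this read-out lower numbers stand for less inhibition and higher numbers for more inhibition at the one concentration tested (going by the name of the read-out)), level with compound 1 `Cc1n[nH]c2ccc(-c3nc4cnc(N5CCN(C)CC5)cn4c3Nc3ccccc3F)cc12` at 0%; together these are the lowest of the three numbers, while compound 2 `Cc1n[nH]c2ccc(-c3nc4cnc(N5CCN(C)CC5)cn4c3Nc3ccc(Cl)cc3)cc12` reaches 83.7%. The step of a number 83.7 percentage points lower from compound 2 to compound 3 (beyond the scatter) and the step of a number 83.7 percentage points higher from compound 1 to compound 2 (beyond the scatter) are both large. Compound 4 `Cc1n[nH]c2ccc(-c3nc4cnc(N5CCN(C)CC5)cn4c3Nc3ccc(F)cc3Br)cc12` differs from compound 3 by 2-bromo-4-fluorophenyl in place of 4-chloro-2-fluorophenyl on a nitrogen on an aromatic ring. Among the measured compounds shown here, no measured step covers bromo in place of fluoro or fluoro in place of chloro, so the relevant guidance is that compound 1 and compound 3, each bearing a 2-fluorophenyl or 4-chloro-2-fluorophenyl group, show no inhibition. For compound 4 the estimate is 5% with a range of 0% to 35%, an expected step of a number 5 percentage points higher from compound 3 to compound 4 (within the scatter) in this assay.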

Compound 4, a percentage reported as inhibition, at one concentration (the size of the read-out at that concentration, not a potency): 82.4%
For compound 4 the middle estimate is 77.4 percentage points below the measured one; measured number outside the range, above it.
By their numbers in this assay, from the lowest: compounds 1 and 3 (each within the scatter of the next); then compounds 4 and 2 (each within the scatter of the next).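

In this assay the change to 2-bromo-4-fluorophenyl gives a number 82.4 percentage points higher from compound 3 to compound 4 (beyond the scatter) and also a number 82.4 percentage points higher from compound 1 to compound 4 (beyond the scatter) so the loss seen with 4-chloro-2-fluorophenyl does not extend to every anilino ring carrying two halogens. With a number 1.3 percentage points lower from compound 2 to compound 4 (within the scatter) as the remaining step, this group stands level with 4-chlorophenyl. Nothing at hand explains these steps.

Which of the bromo and fluoro groups carries the recovery stays open, since neither is varied alone here. Methoxy or trifluoromethyl groups on this ring also remain untested in the compounds shown.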